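Adding a hydroxymethyl group to compound 1

This account rests on a few compounds, and the source may have more. Where it says the series, first, only, none or still open, it means among the compounds named here.

Compound 1, with the structure `CCOC(=O)c1c(-c2ccccc2)[nH]c2cc(OC)ccc2c1=O`, is a small molecule carrying a phenyl group on its shared core. In an ADME assay on Raji cells (Homo sapiens) for cytotoxicity, read by luminescence, with a stated time of 72 h (on this read-out lower numbers stand for an effect already at smaller amounts and higher numbers for an effect only at larger amounts of compound), compound 1 gives only a limit of the assay, > 21500 nM, and no exact number. A close relative, compound 2, with the structure `CCCOc1cccc(-c2[nH]c3cc(OC)ccc3c(=O)c2C(=O)OCC)c1`, differs in one place, namely propoxy in place of hydrogen on an aromatic carbon. In this assay compound 2 likewise reaches only a limit, > 21500 nM. For the measured compounds named here, the step that the two limits leave unreadable from compound 1 to compound 2 therefore cannot be read in size or direction, since the limit of > 21500 nM in this assay, at which 2 of the 2 values shown sit, covers every value so far.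

Compound 3, with the structure `CCOC(=O)c1c(-c2cccc(CO)c2)[nH]c2cc(OC)ccc2c1=O`, is not yet measured. It differs from compound 1 as follows: hydroxymethyl in place of hydrogen on an aromatic carbon. Going by the values given here, no measured step yet involves a hydroxymethyl group, and the only step known, from compound 1 to compound 2, is unreadable. The expectation is thus simply that compound 3 behaves like compound 1 in this assay, with an expected step that the limit leaves unreadable from compound 1 to compound 3. Compound 3 is estimated at 25000 nM, within a range from 8000 nM to 80000 nM, most likely again reported only as a limit.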

Compound 3, half-maximal effective concentration: > 21500 nM
Compound 3 gave a limit, no number; the forecaster's own chance of this, stated with the estimate: 80%; the middle value lies beyond the limit too.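

In this assay compound 3 gives only a limit and no exact number, so its steps from compound 1 and from compound 2 cannot be read in size or direction: the limit of > 21500 nM in this assay, at which 3 of the 3 values shown sit. The compounds shown leave open whether hydroxymethyl or propoxy in place of hydrogen changes this read-out at all, and how compound 1, compound 2 and compound 3 rank.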